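Swapping the fluorophenyl of compound 1 for a thiophene

The compounds below may be only part of what the source reports. "The series", "measured", "known", "first", "only" and "open" are said of these compounds alone.

Of the compounds shown here, three sharing one core have been tested in an assay on HEK293 cells for displacement of a labelled ligand from 5-hydroxytryptamine receptor 6 (Homo sapiens); on this read-out higher numbers stand for weaker inhibition and lower numbers for stronger inhibition. Compound 1 `CN1CCN(c2nc(N)nc(Cc3ccccc3F)n2)CC1` gives 88 nM, the lowest of the three numbers. Compound 2 `COc1ccccc1Cc1nc(N)nc(N2CCN(C)CC2)n1` gives 193 nM, and compound 3 `COc1ccc(Cc2nc(N)nc(N3CCN(C)CC3)n2)cc1` gives 440 nM. For the measured compounds named here, the only single-change step measured, a 2.2-fold higher number from compound 1 to compound 2 (0.34 log units; beyond the scatter), concerns a different kind of change than the one now asked about.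

Compound 4 `CN1CCN(c2nc(N)nc(Cc3cccs3)n2)CC1` differs from compound 1 by thiophen-2-yl in place of 2-fluorophenyl on a saturated chain carbon bound to an aromatic carbon. Going by the values given here, no measured step covers an exchange of one aromatic ring for another, so the expectation rests only on the small size of the change seen so far. Compound 4 is therefore expected to show a modest shift towards a higher number, a 1.7-fold higher number from compound 1 to compound 4 (0.23 log units; within the scatter), giving an estimated 150 nM with a range from 60 nM to 400 nM.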

Compound 4, inhibition constant: 305 nM
Estimate against measurement, compound 4: 2.0-fold (0.31 log units) below; measured number inside the range.
By their numbers in this assay, from the lowest: compound 1; then compounds 2, 4 and 3 (each within the scatter of the next, the first and the last beyond it).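

In this assay the step for thiophen-2-yl in place of 2-fluorophenyl is a 3.5-fold higher number from compound 1 to compound 4 (0.54 log units; beyond the scatter) and shows that this place on the saturated chain carbon responds to exchanging the whole ring, not only to changing a group on it. Of these two rings, the 2-fluorophenyl of compound 1 gives the stronger inhibition. Nothing available explains this difference.

On these data alone, what a pyridin-2-yl ring or a cyclohexyl group would give at this place remains open. So does whether a fluoro group on the thiophene ring would lower the number again.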